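Thioether benzamide series: ring substituent change on the sulfur

The source may hold more compounds than are shown below. What is called first, only, known or untested is meant among the compounds shown, and "the series" means these compounds.

Measured so far:
compound 1, `Nc1ccccc1NC(=O)/C=C/c1ccc(CSc2ccc(Cl)cc2)cc1`, 5.62%
compound 2, `COc1ccc(SCc2ccc(C(=O)Nc3ccccc3N)cc2)cc1`, 73.3%
compound 3, `CC(C)(C)c1ccc(SCc2ccc(C(=O)Nc3ccccc3N)cc2)cc1`, 4.81%

In a functional assay on HCT-116 cells (Homo sapiens) for inhibition, read by CCK-8 assay, with a stated time of 72 h, tested at 2 uM (a higher number here means more inhibition of growth at the concentration tested, a lower number less inhibition of growth), compound 2 stands highest of the three numbers; compound 1 lies below it beyond the scatter, and compound 3 lies furthest below it, also beyond the scatter. Compound 1 carries a different core and no step to it is counted, so only its value is taken as shown.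

The next compound, compound 4, `Cc1cc(C)cc(SCc2ccc(C(=O)Nc3ccccc3N)cc2)c1`, is not yet measured. It differs from compound 2 in one place: 3,5-dimethylphenyl in place of 4-methoxyphenyl on a sulfur.

For the measured compounds named here, the one measured step that bears on this is the change at the same aromatic ring, a number 68.5 percentage points lower from compound 2 to compound 3 (beyond the scatter). That step replaced a group carrying one hydrogen-bond acceptor with one carrying none, and the growth inhibition fell sharply. The change to compound 4 also removes the single hydrogen-bond acceptor, though the entering group is different in shape. Going by the values given here, a downward step in this assay is therefore expected, likely large, but with wide uncertainty since only one such step is known.

For compound 4 the estimated step is a number 51.3 percentage points lower from compound 2 to compound 4 (beyond the scatter), giving an expected value of 22%, in the range 4% to 60%.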

Compound 4, percent growth inhibition at one concentration: 3.22%
Beside the measured number, compound 4's estimate is 18.8 percentage points above it; measured number below the stated range.
By their numbers in this assay, from the lowest: compounds 4, 3 and 1 (each within the scatter of the next); then compound 2.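

In this assay the move to 3,5-dimethylphenyl on the sulfur reads as a number 70.1 percentage points lower from compound 2 to compound 4 (beyond the scatter) and is large, so the loss seen with the tert-butyl group is not tied to that one group or to a single substitution pattern. Compound 3 at 4.81% and compound 4 at 3.22% lie within the scatter of each other even though their entering groups are arranged differently on the ring, and among the compounds sharing this core only compound 2, with its methoxy oxygen, keeps a high number at 73.3%. No measurement at hand accounts for this fall in growth inhibition, so the link with the methoxy group remains a correspondence across these three compounds only.

The compounds shown leave open whether the oxygen itself or the whole 4-methoxyphenyl group carries the inhibition, a question that a 4-hydroxyphenyl, 4-ethoxyphenyl or 3,5-dimethoxyphenyl group on the sulfur would address. For the compounds shown here, they also leave open how a plain phenyl or a 4-methylphenyl group would read, and with compound 2 as the only high value, the series has no second high point for comparison.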